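The source may hold more compounds than are shown below. What is called first, only, known or untested is meant among the compounds shown, and "the series" means these compounds.

Working notes on the series, read in an in vitro ADME assay on microsomes from liver (Homo sapiens) for metabolic stability, in the presence of a further agent that is not named here; a lower number here means slower removal, a higher number faster removal of the compound. Compound 1 (`CC(C)(CO)CNC(=O)c1cc2cc(C#N)ccc2n1Cc1cc(Cl)cc(Cl)c1`) gives 22 mL.min-1.g-1, compound 2 (`COc1ccc(C)cc1Cn1c(C(=O)NCC(C)(C)CO)cc2cc(C#N)ccc21`) gives 23 mL.min-1.g-1, and compound 3 (`Cc1ccc(C(F)(F)F)cc1Cn1c(C(=O)NCC(C)(C)CO)cc2cc(C#N)ccc21`) gives 16 mL.min-1.g-1. All three numbers lie within the scatter of one another, so compound 3 stands level with compound 1 and compound 2 on this read-out.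

The next compound is compound 4 (`Cc1ccc(Cl)cc1Cn1c(C(=O)NCC(C)(C)CO)cc2cc(C#N)ccc21`), and its difference from compound 3 is chloro in place of trifluoromethyl on an aromatic carbon. The group that is exchanged sits meta to a large group and para to a methyl group.

Among the measured compounds shown here, no measured pair makes this exact exchange. For the measured compounds named here, the one measured step that bears on it is indirect: a 1.0-fold higher number from compound 1 to compound 2 (0.02 log units; within the scatter), with 2-methoxy-5-methylphenyl in place of 3,5-dichlorophenyl. That step stays within the scatter even though the aryl group changes at more than one place. Compound 1, which carries chloro groups on its aryl ring, reads 22 mL.min-1.g-1, so chloro as such gives no sign of a departure from the series.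

No change beyond the scatter is therefore expected, and the expected step is a 1.2-fold higher number from compound 3 to compound 4 (0.07 log units; within the scatter). Compound 4 is estimated at 19 mL.min-1.g-1, with an expected range from 11 mL.min-1.g-1 to 31 mL.min-1.g-1.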

Compound 4, intrinsic clearance in microsomes: 23 mL.min-1.g-1
Estimate against measurement, compound 4: 1.2-fold (0.08 log units) below; the measured number falls inside the stated range.
By their numbers in this assay, from the lowest: compounds 3, 1, 2 and 4 (each within the scatter of the next).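

In this assay, trifluoromethyl and chloro on the aromatic carbon meta to a large group and para to a methyl group are now compared directly, and the exchange gives a 1.4-fold higher number from compound 3 to compound 4 (0.16 log units; within the scatter), so the read-out does not separate these two groups at this position. Comparison of the whole aryl group gives no change at the digits printed from compound 2 to compound 4 (within the scatter) and a 1.0-fold higher number from compound 1 to compound 4 (0.02 log units; within the scatter), which places 5-chloro-2-methylphenyl level with both 2-methoxy-5-methylphenyl and 3,5-dichlorophenyl, and all four compounds remain within the scatter of one another. No measurement is available that accounts for this flat reading.

It remains open whether an amine, a carboxylic acid or a longer chain in place of chloro at this position would stay within the scatter, since the compounds shown carry only small uncharged groups there, with no hydrogen-bond donors or acceptors in the two exchanged groups. The nitrile and the amide side chain are the same in all four compounds, so these compounds say nothing about how changes at either place would read in this assay.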